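Three amides on a shared core, and a hydroxy replacing a methyl

This account rests on a few compounds, and the source may have more. Where it says the series, first, only, none or still open, it means among the compounds named here.

Measured in an ADME assay on microsomes from liver (Homo sapiens) for metabolic stability; on this read-out lower numbers stand for a shorter-lived compound and higher numbers for a longer-lived compound:
- compound 1, `O=C(Nc1cc(Oc2ccc(Nc3nccc4[nH]cc(-c5ccc(F)cc5)c(=O)c34)cc2F)ccn1)C1CC1`, gives 13.2 h
- compound 2, `CC(O)C(=O)Nc1cc(Oc2ccc(Nc3nccc4[nH]cc(-c5ccc(F)cc5)c(=O)c34)cc2F)ccn1`, gives 4.15 h
- compound 3, `CCC(=O)Nc1cc(Oc2ccc(Nc3nccc4[nH]cc(-c5ccc(F)cc5)c(=O)c34)cc2F)ccn1`, gives 2.72 h

Compound 3 has the lowest number of the three in this assay. Its gap to compound 1 is real, a 4.9-fold lower number from compound 1 to compound 3 (0.69 log units; beyond the scatter), whereas its gap to compound 2 is small, a 1.5-fold lower number from compound 2 to compound 3 (0.18 log units; within the scatter), so compound 2 and compound 3 cannot be told apart. Compound 1 also stands apart from compound 2, a 3.2-fold lower number from compound 1 to compound 2 (0.50 log units; beyond the scatter).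

Compound 4, `O=C(CO)Nc1cc(Oc2ccc(Nc3nccc4[nH]cc(-c5ccc(F)cc5)c(=O)c34)cc2F)ccn1`, is reached from compound 3 by one change: hydroxy in place of methyl on a saturated chain carbon bound to a carbonyl carbon. Within the data shown here, the only measured step that touches this place is the one between compound 2 and compound 3, where a hydroxy was removed from the saturated chain carbon and the number moved only within the scatter. Among the measured compounds shown here, the present change differs in that the hydroxy takes the place of a methyl rather than of a hydrogen, so no measured step covers it exactly.

Compound 4 is therefore expected to stay close to compound 3 in this assay, with at most a small rise, a 1.3-fold higher number from compound 3 to compound 4 (0.10 log units; within the scatter). The estimate for compound 4 is 3.4 h, within 1.7 h to 7 h.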

Compound 4, half-life: 7.23 h
Estimate against measurement, compound 4: 2.1-fold (0.33 log units) below, outside the stated range (above it).
By their numbers in this assay, from the lowest: compounds 3, 2, 4 and 1 (each within the scatter of the next, the first and the last beyond it).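

In this assay, putting hydroxy in place of methyl on the saturated chain carbon bound to a carbonyl carbon gives a step beyond the scatter, a 2.7-fold higher number from compound 3 to compound 4 (0.42 log units; beyond the scatter), whereas the earlier step at this place, a 1.5-fold lower number from compound 2 to compound 3 (0.18 log units; within the scatter), stayed within it. The hydroxymethyl group on the carbonyl carbon also brings the series to a point where neighbouring amides can no longer be separated, with a 1.7-fold higher number from compound 2 to compound 4 (0.24 log units; within the scatter) and a 1.8-fold lower number from compound 1 to compound 4 (0.26 log units; within the scatter) both within the scatter, although compounds 2 and 3 each stood apart from the cyclopropyl amide. Nothing available accounts for this result.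

The compounds shown leave open whether the hydroxy group itself matters, since a methoxy group on the same chain carbon would separate its presence from that of the oxygen alone. They also leave open how an amine or a longer hydroxyalkyl chain would behave here.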